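Removing One Methyl on Two Closely Related Cores

The source may hold more compounds than are shown below. What is called first, only, known or untested is meant among the compounds shown, and "the series" means these compounds.

Compound 1 `COc1cc(-c2nn(-c3cccc(NC(=O)Nc4cc(C(F)(F)F)cc(C(F)(F)F)c4)c3)cc2-c2ccncc2)ccc1Cl` and compound 3 `COc1cc(-c2nn(-c3cccc(NC(=O)Nc4ccc(Cl)c(C(F)(F)F)c4)c3)cc2-c2ccncc2)ccc1Cl` share most of their framework, though the difference between their two cores is not broken down here. Both were tested in a functional assay on MDA-MB-468 cells (Homo sapiens) for inhibition, read by sulforhodamine B assay, with a stated time of 48 h; on this read-out higher numbers stand for lower toxicity in this test and lower numbers for higher toxicity in this test. In this assay compound 1 gives 24300 nM. Compound 2 `O=C(Nc1cccc(-n2cc(-c3ccncc3)c(-c3ccc(Cl)c(O)c3)n2)c1)Nc1cc(C(F)(F)F)cc(C(F)(F)F)c1` carries hydrogen in place of methyl on an oxygen on an aromatic ring relative to compound 1, and in this assay compound 2 gives 37100 nM; the step of a 1.5-fold higher number from compound 1 to compound 2 (0.18 log units; within the scatter) is small. For compound 3 this assay gives only a limit, > 32500 nM, and the limit of > 32500 nM in this assay, at which 1 of the 3 values shown sits, records that limit.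

Compound 4 `O=C(Nc1cccc(-n2cc(-c3ccncc3)c(-c3ccc(Cl)c(O)c3)n2)c1)Nc1ccc(Cl)c(C(F)(F)F)c1` has not yet been measured. It stands to compound 3 as compound 2 stands to compound 1, carrying (hydrogen in place of methyl on an oxygen on an aromatic ring); the place of the change is described in the same words in both pairs, so it is the same change. Because the first occurrence gave only a 1.5-fold higher number from compound 1 to compound 2 (0.18 log units; within the scatter), a step within the usual scatter, a similarly small shift is expected here, and the expected step is a step that the limit leaves unreadable from compound 3 to compound 4. Compound 4 is therefore estimated at 45000 nM in this assay, within an expected range from 22000 nM to 95000 nM, with a real chance that only a limit is reported again.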

Compound 4, concentration lethal to 50% of the cells: > 32500 nM
Compound 4 ended at the assay's limit; the forecaster's own chance of this, stated with the estimate: 65%; the middle value lies beyond the limit too.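

In this assay compound 4 gives > 32500 nM as a limit and not as a number. For the compounds shown here, compound 3 also gives only a limit, so no step between compound 3 and compound 4 can be read: the limit of > 32500 nM in this assay, at which 2 of the 4 values shown sit. The compounds shown leave open what methoxy to hydroxy does in this pair, and how far past the limit either compound lies.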